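A few compounds are considered here, and "the series" means these few. Any claim that something is new, unique, unknown or untested is made for them only; others in the source may bear on it.

Measured so far in a functional assay, read by spectrophotometry, with a stated time of 1 h; on this read-out lower numbers stand for stronger inhibition and higher numbers for weaker inhibition:
compound 1 `O=c1[nH]c2ccccc2cc1/C=N/c1ccccc1O`: 1660000 nM
compound 2 `Cc1ccc2[nH]c(=O)c(/C=N/O)cc2c1`: 1980000 nM
compound 3 `O=c1[nH]c2ccccc2cc1/C=N/O`: 2010000 nM

Compound 3 stands at the highest of the three numbers in this assay, but both its neighbours sit within the scatter of it. Among the measured compounds shown here, the one single-point step measured, a 1.0-fold higher number from compound 2 to compound 3 (0.01 log units; within the scatter), concerns hydrogen in place of methyl on an aromatic carbon and lies within the scatter. Compound 1 and compound 3 differ at the double-bonded nitrogen, and their two values also sit within the scatter of each other.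

Compound 4 `N/N=C/c1cc2ccccc2[nH]c1=O` differs from compound 3 by amino in place of hydroxy on a double-bonded nitrogen. For the measured compounds named here, no measured step bears directly on this exchange. On the numbers shown for compound 1, compound 2 and compound 3, no step beyond the scatter is expected in this assay for compound 4, so the expected step is a 1.1-fold lower number from compound 3 to compound 4 (0.05 log units; within the scatter). Compound 4 is thus estimated at 1800000 nM, with a range of 800000 nM to 4000000 nM.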

Compound 4, half-maximal inhibitory concentration: 365000 nM
Compound 4: the middle estimate sits 4.9-fold (0.69 log units) above what was measured; the measured number lies below the stated range.
By their numbers in this assay, from the lowest: compound 4; then compounds 1, 2 and 3 (each within the scatter of the next).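

In this assay, among the compounds shown here, the double-bonded nitrogen is the one place in these compounds where a single change gives a step beyond the scatter: amino in place of hydroxy brings a 5.5-fold lower number from compound 3 to compound 4 (0.74 log units; beyond the scatter), a modest step. Hydrogen in place of methyl on an aromatic carbon, by contrast, stayed within the scatter, with a 1.0-fold higher number from compound 2 to compound 3 (0.01 log units; within the scatter). Nothing available explains the step at the double-bonded nitrogen.

Going by these compounds, whether a methylamino, dimethylamino or methoxy group on this nitrogen would hold the lower number remains open. So does whether methyl on an aromatic carbon stays within the scatter when amino is present.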